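The source may hold more compounds than are shown below. What is called first, only, known or untested is meant among the compounds shown, and "the series" means these compounds.

The study sets two imines on a shared core side by side. Compound 1 `C/C(=N\c1nc(NC2CC2)c2ncn(C3C=CC(CO)C3)c2n1)c1ccc(O)cc1` carries a phenol on its aryl imine, and in a functional assay on CCRF-CEM cells (Homo sapiens) for cytotoxicity (a higher number here means that more compound is tolerated, a lower number that less compound is tolerated), compound 1 gives 62000 nM. Compound 2 `CN(C)c1ccc(/C=N/c2nc(NC3CC3)c3ncn(C4C=CC(CO)C4)c3n2)cc1` carries a dimethylamino group in the same position of its aryl ring. In this assay compound 2 reaches only a limit, > 100000 nM, so no number is known for it. Going by the values given here, the evidence on the measured compounds is thin: the limit of > 100000 nM in this assay, at which 1 of the 2 values shown sits, and no step between two measured compounds is available to size the effect of a change on the aryl ring.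

Compound 3 `COc1ccc(/C=N/c2nc(NC3CC3)c3ncn(C4C=CC(CO)C4)c3n2)cc1` is the next member. Relative to compound 2 the change is methoxy in place of dimethylamino on an aromatic carbon. Because compound 2 sits at the limit > 100000 nM, the step from it cannot be measured in full. Compound 3 is expected to show a step of an at least 1.1-fold lower number from compound 2 to compound 3 (0.07 log units; that floor lies within the scatter), no more than the scatter would allow. Compound 3 is estimated at 85000 nM, with a range from 40000 nM to 180000 nM.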

Compound 3, half-maximal cytotoxic concentration: > 100000 nM
Compound 3 gave a limit, no number (the forecaster's own chance of this, stated with the estimate: 55%); middle value at least 1.1-fold (0.07 log units) from the limit.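

In this assay, methoxy in place of dimethylamino on an aromatic carbon leaves compound 3 at a limit, as compound 2 already was, so the step between these two limits cannot be read and neither its size nor its direction is known. The comparison with compound 1 does give the series its first step with a floor, an at least 1.6-fold higher number from compound 1 to compound 3 (0.20 log units; that floor lies within the scatter), although it exchanges a whole group of 10 heavy atoms rather than a single substituent and shows no separation beyond the usual scatter. The new information is therefore that a second aryl imine on the shared core, not just one, reaches the top of the range that can be read in this assay: the limit of > 100000 nM in this assay, at which 2 of the 3 values shown sit.

The compounds shown leave open whether any substituent at this place on the aromatic ring would give compound 2 or compound 3 an analogue with a measured number, as compound 1 has. It remains to be seen where a 4-aminophenyl or a 4-carboxyphenyl group in the same place would fall in this assay.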